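This account rests on a few compounds, and the source may have more. Where it says the series, first, only, none or still open, it means among the compounds named here.

Measured so far:
compound 1 `S=C(Nc1ccccc1)N1N=C(c2ccccc2)CC1c1ccc2c(c1)OCCO2` — 6630 nM
compound 2 `Fc1ccc(C2=NN(C(=S)Nc3ccccc3)C(c3ccc4c(c3)OCCO4)C2)cc1` — 37600 nM

Both compounds share the same core and were tested in a functional assay on HT-29 cells (Homo sapiens) for antiproliferative activity, read by MTT assay, with a stated time of 48 h; on this read-out lower numbers stand for stronger inhibition of growth and higher numbers for weaker inhibition of growth. Compound 1 gives 6630 nM; compound 2 gives 37600 nM, which is the highest of the two numbers, its nearest neighbour being compound 1 with a 5.7-fold higher number from compound 1 to compound 2 (0.75 log units; beyond the scatter).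

Compound 3 `S=C(Nc1ccccc1)N1N=C(c2ccc(Cl)cc2)CC1c1ccc2c(c1)OCCO2` is the next member of the series. It differs from compound 2 by chloro in place of fluoro on an aromatic carbon; seen one bond further out, a 4-fluorophenyl becomes a 4-chlorophenyl. Within the data shown here, only one measured step touches this position: a 5.7-fold higher number from compound 1 to compound 2 (0.75 log units; beyond the scatter), which came from putting a fluoro where a hydrogen had been. Among the measured compounds shown here, no measured pair shows what swapping one halogen for another does here, so that step gives at best an indirect hint that a halogen at this position is tolerated only weakly.

On this thin basis the expected step from compound 2 to compound 3 in this assay is a 1.3-fold lower number from compound 2 to compound 3 (0.10 log units; within the scatter), not clearly beyond the scatter in either direction. Compound 3 is therefore estimated at 30000 nM, with a range from 8000 nM to 110000 nM.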

Compound 3, concentration for 50% growth inhibition: 187000 nM
For compound 3 the middle estimate is 6.2-fold (0.79 log units) below the measured one; the whole stated range lies below it.
By their numbers in this assay, from the lowest: compound 1; then compound 2; then compound 3.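

In this assay, chloro in place of fluoro gives a 5.0-fold higher number from compound 2 to compound 3 (0.70 log units; beyond the scatter) and so shows that the identity of the halogen matters at this position, not merely whether one is present. Compared with hydrogen at the same aromatic carbon, chloro gives a 28-fold higher number from compound 1 to compound 3 (1.45 log units; beyond the scatter) and extends the picture: both halogens come with weaker inhibition of growth, and on these three compounds the numbers rise from hydrogen to fluoro to chloro. Nothing available here accounts for this order.

Three compounds cannot show whether the rise continues with a bromo group, or how groups of a different kind, such as a methyl, a methoxy or an amine, would behave at this same place. On these data alone, it also remains open whether fluoro and chloro would rank the same way on another aromatic ring of the shared core, so the order seen here is best read as a fact about this one position in these compounds rather than as a general rule.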